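Shrinking the Ring Amine at the End of a Ketone Chain

This account rests on a few compounds, and the source may have more. Where it says the series, first, only, none or still open, it means among the compounds named here.

In an assay on cells for inhibition of Amine oxidase [flavin-containing] A (Homo sapiens), read by fluorescence, spectrophotometry and Amplex Red, with stated times of 60 min and 30 min (a higher number here means a weaker inhibitor, a lower number a stronger inhibitor), compound 3 `COc1ccc2cc(C(=O)CCN3CCCCC3)c(=O)oc2c1` gives 12200 nM, the upper of the two numbers shown. Compound 2 `COc1ccc2cc(C(=O)CCN(C)C)c(=O)oc2c1` gives 7630 nM in this assay, and the step of a 1.6-fold higher number from compound 2 to compound 3 (0.20 log units; within the scatter) lies within the scatter. Compound 1 `O=C(CCN1CCCC1)c1cc2ccc(O)cc2oc1=O` reaches only a limit of the assay, > 200000 nM, in this assay; this is the limit of > 200000 nM in this assay, at which 1 of the 3 values shown sits. Compound 4 `COc1ccc2cc(C(=O)CCN3CCCC3)c(=O)oc2c1` differs from compound 3 by pyrrolidin-1-yl in place of piperidin-1-yl on a saturated chain carbon, two bonds along the chain from a carbonyl carbon. Going by the values given here, the one measured step that bears on this exchange, a 1.6-fold higher number from compound 2 to compound 3 (0.20 log units; within the scatter), also swapped one amine for another at the same place and moved the number only within the scatter, so the step of a 1.2-fold lower number from compound 3 to compound 4 (0.09 log units; within the scatter) is expected to stay within the scatter as well. Compound 4 is therefore estimated at 10000 nM in this assay, expected to fall between 4000 nM and 25000 nM.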

Compound 4, half-maximal inhibitory concentration: 53100 nM
Compound 4: middle estimate off by 5.3-fold (0.73 log units), on the low side; the whole stated range lies below it.
By their numbers in this assay, from the lowest: compounds 2 and 3 (each within the scatter of the next); then compound 4. At a limit, above all of these: compound 1.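

Going from the six-membered to the five-membered ring at this place changes the result: (a 4.4-fold higher number from compound 3 to compound 4 (0.64 log units; beyond the scatter)) is a step beyond the scatter, whereas the earlier exchange of dimethylamino for piperidin-1-yl stayed within it. The comparison with the open-chain amine points the same way (a 7.0-fold higher number from compound 2 to compound 4 (0.84 log units; beyond the scatter)), so pyrrolidin-1-yl stands apart from both other amines in this assay. With methyl in place of hydrogen on the oxygen on the aromatic ring, the step (an at least 3.7-fold lower number from compound 1 to compound 4 (0.57 log units; beyond the scatter)) rests on a limit of the assay: the limit of > 200000 nM in this assay, at which 1 of the 4 values shown sits.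

What the compounds shown leave open is where a morpholine ring, a seven-membered azepane ring or an open-chain diethylamino group would fall at this place. Also open is why the five-membered ring differs from the six-membered one, as nothing shown bears on that.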